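Aryl groups on the amine nitrogen and U2OS growth inhibition

The source may report more compounds than this note shows. Statements on the series, on what has been measured and on what is new or still open speak of the compounds shown alone.

Measured compounds:
- Compound 1 `O=C(C1=C(O)C(=O)N(CCCn2ccnc2)C1c1ccc(Br)cc1)c1ccccc1`: "not active" (no number reported) in a functional assay on U2OS cells (Homo sapiens) for antiproliferative activity, read by MTT assay, with a stated time of 72 h; on this read-out higher numbers stand for weaker inhibition and lower numbers for stronger inhibition (no number reported)
- Compound 2 `NC1=C(C(=O)c2ccccc2)C(c2ccc(Br)cc2)N(CCCn2ccnc2)C1=O`: 149000 nM
- Compound 3 `O=C(C1=C(Nc2ccc(Cl)cc2)C(=O)N(CCCn2ccnc2)C1c1ccc(Br)cc1)c1ccccc1`: 22800 nM

Compound 2 gives the highest of the two numbers in this assay. Among the measured compounds shown here, its nearest neighbour is compound 3, and that step, a 6.5-fold lower number from compound 2 to compound 3 (0.82 log units; beyond the scatter), is the only measured step in the set. For the measured compounds named here, compound 1 was reported as inactive without a number, so it gives no step to compare.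

Compound 4 `O=C(C1=C(Nc2cccc(Br)c2)C(=O)N(CCCn2ccnc2)C1c1ccc(Br)cc1)c1ccccc1` is the unmeasured compound. It differs from compound 2 by a single change: 3-bromophenyl in place of hydrogen on an amine nitrogen

Going by the values given here, the one step that bears on this change is the step from compound 2 to compound 3, where 4-chlorophenyl entered on the same amine nitrogen and the number fell, a 6.5-fold lower number from compound 2 to compound 3 (0.82 log units; beyond the scatter). Among the compounds with values here, the change to compound 4 puts a 3-bromophenyl on that nitrogen instead, a difference of one ring substituent and its placement, for which no measured step exists. The expectation therefore leans on compound 3 alone: a lower number than compound 2, of modest size, with wide uncertainty.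

Compound 4 is expected to give 25000 nM, with a range from 8000 nM to 80000 nM. This estimate corresponds to an expected 6.0-fold lower number from compound 2 to compound 4 (0.78 log units; beyond the scatter).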

Compound 4, half-maximal inhibitory concentration: 11900 nM
Compound 4: the middle estimate sits 2.1-fold (0.32 log units) above what was measured, and the stated range covers the measured number.
By their numbers in this assay, from the lowest: compounds 4 and 3 (each within the scatter of the next); then compound 2.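

In this assay, 3-bromophenyl on the amine nitrogen gives a 13-fold lower number from compound 2 to compound 4 (1.10 log units; beyond the scatter) and so shows that the lower number seen with compound 3 is not confined to one aryl group, since the trend now rests on two compounds with different ring substituents. Between the two aryl groups the comparison reads a 1.9-fold lower number from compound 3 to compound 4 (0.28 log units; within the scatter) and so this assay does not separate 3-bromophenyl from 4-chlorophenyl, even though both the halogen and its placement on the ring differ. Nothing in the data at hand explains why an aryl group on this nitrogen goes with a lower number than the free amino group.

On these data alone, it remains open whether the ring alone accounts for the step or the halogen contributes, which an unsubstituted phenyl, a benzyl or a simple methyl group on the same nitrogen would help to decide. Compound 3 and compound 4 differ in halogen and placement at once. 4-bromophenyl and 3-chlorophenyl would be needed to tell those two apart.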